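A 1,3-benzothiazol-2-yl swap on compound 2

This account rests on a few compounds, and the source may have more. Where it says the series, first, only, none or still open, it means among the compounds named here.

Measured so far in a physicochemical assay for solubility, read by chemiluminescence, in phosphate buffer, measured as kinetic solubility, at pH 7.4 (a higher number here means a more soluble compound, a lower number a less soluble compound), are three compounds:
Compound 1 `O=C(NCC1(c2nc(-c3ccccc3)cs2)CCOCC1)c1ccc(-n2cncn2)cc1` gives 191000 nM
Compound 2 `Cc1cnc(Nc2ccc(C(=O)NCC3(c4nc(-c5ccccc5)cs4)CCOCC3)cc2)s1` gives < 1000 nM as a limit
Compound 3 `Cc1cc(C)n(Cc2ccc(C(=O)NCC3(c4ccccn4)CCOCC3)cc2)n1` gives >= 445000 nM as a limit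

Compound 2 reads < 1000 nM in this assay and this is a limit of the assay, not a number. Compound 4 `O=C(NCC1(c2nc(-c3ccccc3)cs2)CCOCC1)c1ccc(Nc2nc3ccccc3s2)cc1` differs from it in one place: 1,3-benzothiazol-2-yl in place of 5-methyl-1,3-thiazol-2-yl on a nitrogen on an aromatic ring. In words, 1,3-benzothiazol-2-yl stands in place of 5-methyl-1,3-thiazol-2-yl on a nitrogen on an aromatic ring. Among the measured compounds shown here, one measured step bears on this, and only indirectly: the large change an at least 190-fold lower number from compound 1 to compound 2 (2.28 log units; beyond the scatter) came with (5-methyl-1,3-thiazol-2-yl)amino in place of 1H-1,2,4-triazol-1-yl on an aromatic carbon. For the measured compounds named here, no measured step exchanges one such amino group for another. With compound 2 at its limit and compound 4 keeping an amino group of this kind, no large change is expected. The expected step is a step that the limit leaves unreadable from compound 2 to compound 4 and the assay may well report only a limit again. Compound 4 is estimated at 600 nM and expected to lie between 200 nM and 1000 nM in the measurement to come.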

Compound 4, solubility: 4000 nM
Compound 4: middle estimate off by 6.7-fold (0.82 log units), on the low side; measured number outside the range, above it.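

In this assay, among the compounds shown here, this is the first measured exchange of one amino-linked group for another on a nitrogen on an aromatic ring, and it gives an at least 4.0-fold higher number from compound 2 to compound 4 (0.60 log units; beyond the scatter). The true size of that step cannot be read, because compound 2 stands only at a limit of the assay: the limit of < 1000 nM in this assay, at which 1 of the 4 values shown sits. Even with 1,3-benzothiazol-2-yl in place, a large gap remains to the 1H-1,2,4-triazol-1-yl group, with a 48-fold lower number from compound 1 to compound 4 (1.68 log units; beyond the scatter).

The added six-membered aromatic ring and the lost methyl change together in this single step, and the compounds shown do not separate the two. They also leave open how an unsubstituted 1,3-thiazol-2-yl or a pyridin-2-yl on the same nitrogen would read in this assay.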